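The source may hold more compounds than are shown below. What is called first, only, known or untested is meant among the compounds shown, and "the series" means these compounds.

Measured so far in a functional assay on COLO 205 cells (Homo sapiens) for antiproliferative activity, read by sulforhodamine B assay, with a stated time of 72 h; a lower number here means a stronger inhibitor, a higher number a weaker inhibitor:

- compound 1 `O=S(=O)(Nc1ncccn1)c1ccc(Nc2nncc3ccccc23)cc1` gives 43 nM
- compound 2 `Clc1ccc(C(/C=C/c2ccccc2)=N\Nc2nncc3ccccc23)cc1` gives 5.7 nM
- compound 3 `Fc1ccc(Nc2nncc3ccccc23)cc1` gives 4.5 nM

Compound 3 gives 4.5 nM and stands level with compound 2 within the usual scatter of repeated measurements, while compound 1 , at 43 nM, has a higher number, beyond that scatter. Within the data shown here, no two measured compounds differ in one place only, so the set holds no direct measure of what a single change does.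

The next compound to be read is compound 4 `N#Cc1ccc(Nc2nncc3ccccc23)cc1`, which carries cyano in place of fluoro on an aromatic carbon, para to a large group. The counted difference is cyano in place of fluoro on an aromatic carbon and no ring is involved. Among the measured compounds shown here, with no measured step to lean on, the size of this change in this assay can only be judged loosely. Compound 1 at 43 nM shows how far upward the numbers of this small set reach, so a modest rise is expected rather than a fall, and it may not clear the scatter. The expected change is a 2.7-fold higher number from compound 3 to compound 4 (0.43 log units; beyond the scatter) in this estimate. For compound 4 the estimated value is 12 nM, with an expected range from 3 nM to 50 nM.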

Compound 4, half-maximal inhibitory concentration: 2.5 nM
Compound 4: middle estimate off by 4.8-fold (0.68 log units), on the high side; measured number below the stated range.
By their numbers in this assay, from the lowest: compounds 4, 3 and 2 (each within the scatter of the next, the first and the last beyond it); then compound 1.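

In this assay, cyano in place of fluoro on an aromatic carbon, para to a large group, gives a 1.8-fold lower number from compound 3 to compound 4 (0.26 log units; within the scatter) and so leaves the two compounds level. Among these compounds, this is the only comparison so far that isolates a single change, and it replaces the indirect reading of the set with a direct one. At this position, a group of two heavy atoms with one hydrogen-bond acceptor stands in for a single fluorine with no hydrogen-bond acceptor, and the number does not move beyond the usual scatter. Nothing measured here accounts for the two groups reading alike.

Going by these compounds, two groups at one position do not define what this carbon tolerates, so it remains open whether an amine, a methoxy group or a carboxylic acid in the same place would hold the same level. Among the compounds shown here, it also remains open whether the exchange of fluoro for cyano would read the same way on a core other than the one shared by compound 3 and compound 4.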